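Adding an isobutyl group to a potent pyridyl ether

The compounds below may be only part of what the source reports. "The series", "measured", "known", "first", "only" and "open" are said of these compounds alone.

Compound 1, `CN1CCC[C@H]1COc1cccnc1`, is the anchor of this small set. In an assay on membranes from brain for displacement of a labelled ligand from Neuronal acetylcholine receptor; alpha4/beta2 (Rattus norvegicus) (a lower number here means a stronger inhibitor, a higher number a weaker inhibitor), compound 1 gives 0.15 nM, the lowest number of the three measured compounds, so it is the strongest binder seen here. Two relatives carry an extra group on an aromatic carbon of the shared core. Compound 2, `CCN(CC)C(=O)c1ccncc1OC[C@@H]1CCCN1C`, gives 2830 nM, and compound 3, `CN1CCC[C@H]1COc1cnccc1Br`, gives 28 nM. Both steps from the parent are large losses: a 19000-fold higher number from compound 1 to compound 2 (4.28 log units; beyond the scatter), and a 190-fold higher number from compound 1 to compound 3 (2.27 log units; beyond the scatter). Between the two substituted compounds, a 100-fold lower number from compound 2 to compound 3 (2.00 log units; beyond the scatter).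

Compound 4, `CC(C)Cc1cncc(OC[C@@H]2CCCN2C)c1`, is not yet measured. Its change from compound 1 is isobutyl in place of hydrogen on an aromatic carbon. For the measured compounds named here, the two measured steps from compound 1 are the only guide, and both show that a group placed on an aromatic carbon of this core cost affinity heavily, though the group entering here is a small hydrocarbon chain, unlike the diethylcarbamoyl of compound 2 or the bromo of compound 3. A weaker binder than compound 1 is therefore expected, with the step estimated as a 53-fold higher number from compound 1 to compound 4 (1.73 log units; beyond the scatter). For compound 4 the estimate in this assay is 8 nM, within a range from 1.5 nM to 50 nM.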

Compound 4, inhibition constant: 0.21 nM
For compound 4 the middle estimate is 38-fold (1.58 log units) above the measured one; the whole stated range lies above it.
By their numbers in this assay, from the lowest: compounds 1 and 4 (each within the scatter of the next); then compound 3; then compound 2.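

Isobutyl on an aromatic carbon, two atoms from the ring nitrogen and meta to a group of 8 heavy atoms, is tolerated in this assay with a step of a 1.4-fold higher number from compound 1 to compound 4 (0.15 log units; within the scatter) and no real difference in binding. This shows what compounds 2 and 3 could not: placing a group on an aromatic carbon of the shared core does not in itself cost affinity, and this hydrocarbon chain can sit at this place with no change beyond the scatter. Nothing shown explains why isobutyl is accepted here while the diethylcarbamoyl of compound 2 and the bromo of compound 3 come with large losses.

As far as these compounds go, it remains open whether this tolerance extends to a longer chain at the same place, or to a chain ending in an amine or a carboxylic acid. From the compounds shown here alone, it is also open whether isobutyl would fare as well on the aromatic carbons that carry the diethylcarbamoyl of compound 2 or the bromo of compound 3.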